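Sulfone series: aryl swap on the sulfonyl sulfur

The source may report more compounds than this note shows. Statements on the series, on what has been measured and on what is new or still open speak of the compounds shown alone.

Measured so far:
compound 1, `CC(O)(C(=O)Nc1ccc(S(=O)(=O)c2ccccc2F)cc1)C(F)(F)F`: 1300 nM
compound 2, `CC(O)(C(=O)Nc1ccc(S(=O)(=O)c2ccccc2Cl)cc1)C(F)(F)F`: 2300 nM

Both numbers come from a functional assay (Cavia porcellus) with sulfonylurea receptors; K-ATP channels (Homo sapiens) as the target; on this read-out lower numbers stand for stronger inhibition and higher numbers for weaker inhibition. Among the compounds with values here, compound 2 stands at 2300 nM; the only other number, from compound 1, is 1300 nM, and the step of a 1.8-fold higher number from compound 1 to compound 2 (0.25 log units; within the scatter) leaves the two within the scatter, so no order between them can be read.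

Compound 3, `Cc1ccc(S(=O)(=O)c2ccc(NC(=O)C(C)(O)C(F)(F)F)cc2)cc1`, is not yet measured. It differs from compound 2 by 4-methylphenyl in place of 2-chlorophenyl on a sulfonyl sulfur. Within the data shown here, the one measured step, a 1.8-fold higher number from compound 1 to compound 2 (0.25 log units; within the scatter), is the only guide. Among the measured compounds shown here, it exchanged halogens on the same ring and did not move the number beyond the scatter; the change to compound 3 replaces the whole 2-chlorophenyl by 4-methylphenyl, a larger alteration of the group on the sulfonyl sulfur, for which no measured pair gives direct information. For the measured compounds named here, with the single available step small, the working expectation is that compound 3 stays close to compound 2, with a wide range to cover the untested nature of the change.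

The expected step of a 1.2-fold lower number from compound 2 to compound 3 (0.06 log units; within the scatter) is therefore estimated to lie within the scatter. Compound 3 is expected near 2000 nM, in this assay between 700 nM and 6000 nM.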

Compound 3, half-maximal inhibitory concentration: > 30000 nM
Compound 3 ended at the assay's limit; the forecaster's own chance of this, stated with the estimate: 10%; middle value at least 15-fold (1.17 log units) from the limit.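

In this assay compound 3 gives > 30000 nM, which is a limit of the assay and not a number: the limit of > 30000 nM in this assay, at which 1 of the 3 values shown sits.

The group on the sulfonyl sulfur is not freely exchangeable, as 4-methylphenyl in place of the halogenated rings gives an at least 13-fold higher number from compound 2 to compound 3 (1.11 log units; beyond the scatter) and an at least 23-fold higher number from compound 1 to compound 3 (1.36 log units; beyond the scatter), both large, whereas the earlier halogen exchange stayed within the scatter. The leaving 2-chlorophenyl and the entering 4-methylphenyl match in heavy-atom count, in carrying one six-membered aromatic ring of carbon only, and in hydrogen-bond donors and acceptors, so these counts do not track the step.

The change replaces both the substituent and its place on the ring, and the compounds shown do not separate these two contributions. As far as these compounds go, it also stays open whether a plain phenyl, or a ring carrying an amine or a carboxylic acid, on the sulfonyl sulfur would stay near compound 1 and compound 2 or fall at the limit with compound 3.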